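The source may hold more compounds than are shown below. What is called first, only, known or untested is meant among the compounds shown, and "the series" means these compounds.

Working notes on the series.

Three compounds carry numbers in a functional assay on HEp-2 cells (Homo sapiens) for cytotoxicity, read by sulforhodamine B assay, with a stated time of 48 h (on this read-out lower numbers stand for stronger inhibition and higher numbers for weaker inhibition), so far. Compound 1, `COc1cc(C2CC(c3ccco3)=NN2C(C)=O)cc(OC)c1OC`, gives 21300 nM in this assay. Compound 2, `COc1ccc(C2CC(c3cccc4ccccc34)=NN2C(C)=O)c(OC)c1OC`, gives 1290 nM in this assay. Compound 3, `O=CCN1N=C(c2ccc3ccccc3c2)CC1c1cccc(Cl)c1Cl`, gives 12500 nM in this assay. Compound 3 stands second highest of the three numbers; its nearest neighbour is compound 1, whose number is higher but within the scatter, so no order between those two can be read. Compound 2 stands furthest from compound 3, with a lower number, beyond the scatter.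

Compound 4, `COc1ccc(C2CC(c3ccc4ccccc4c3)=NN2CC=O)cc1`, has not yet been measured in this assay. It differs from compound 3 in one place: 4-methoxyphenyl in place of 2,3-dichlorophenyl on a saturated ring carbon. No measured pair in the set isolates this change, so the direction rests on no shown step. The expectation is therefore a step of modest size, in no firm direction, quite possibly none beyond the scatter: the step expected is a 1.3-fold lower number from compound 3 to compound 4 (0.10 log units; within the scatter). In this assay compound 4 is estimated at 10000 nM, with a range from 3000 nM to 30000 nM.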

Compound 4, half-maximal inhibitory concentration: 3230 nM
For compound 4 the middle estimate is 3.1-fold (0.49 log units) above the measured one; the measured number falls inside the stated range.
By their numbers in this assay, from the lowest: compound 2; then compound 4; then compounds 3 and 1 (each within the scatter of the next).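

In this assay the aryl group on the saturated ring carbon is not a silent position: with the naphthyl-bearing remainder of the structure held constant, 4-methoxyphenyl in place of 2,3-dichlorophenyl gives a 3.9-fold lower number from compound 3 to compound 4 (0.59 log units; beyond the scatter) and so moves the number beyond the scatter. Within the data shown here, this is the first pair to isolate a single change, and it shows that this position alone can shift cytotoxicity toward stronger inhibition. Nothing measured here accounts for the step.

The change removes two chlorine atoms and adds a methoxy group at once, so the compounds shown do not tell which of these carries the step; an unsubstituted phenyl or a 4-chlorophenyl at this carbon would separate the two. On these data alone, whether a 4-dimethylaminophenyl or a 4-carboxyphenyl at the same carbon would extend or reverse the step also remains open.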